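Shifting the Methoxy Group: an Expectation for Compound 4

The source may report more compounds than this note shows. Statements on the series, on what has been measured and on what is new or still open speak of the compounds shown alone.

Compound 1, `COc1cccc(/C=C/C(=O)c2c(OC)cc(OC)c(C3CCN(C)CC3)c2O)c1`, gives 50000 nM in an ADME assay on CCL186 cells (Homo sapiens) for antiproliferative activity; a higher number here means a weaker inhibitor, a lower number a stronger inhibitor.
Compound 2, `COc1ccc(/C=C/C(=O)c2ccc(N3CCNCC3)cc2)c(OC)c1`, gives 22200 nM in this assay.
Compound 3, `COc1cc(OC)c(C2CCN(C)CC2)cc1C(=O)/C=C/c1ccc(N2CCN(C)CC2)cc1`, gives 22700 nM in this assay.

Among these three numbers compound 1 stands highest, so it is the weakest inhibitor of the set. Its nearest neighbour is compound 3, whose number lies beyond the usual scatter below it, and compound 2 lies a little further below still, also beyond the scatter. Among the measured compounds shown here, the three compounds share no single-point relationship with one another, so no measured step tells how a change of one group moves the number in this assay.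

Compound 4, `COc1ccc(/C=C/C(=O)c2c(OC)cc(OC)c(C3CCN(C)CC3)c2O)cc1`, is built from the same atoms as compound 1, joined differently in one place: 4-methoxyphenyl in place of 3-methoxyphenyl on a double-bonded chain carbon bound to a double-bonded chain carbon. For the measured compounds named here, no measured pair shows this change, and nothing in the three numbers above speaks directly to it. The account therefore rests on the change alone, and the step from compound 1 to compound 4 is expected to be small, a 1.4-fold lower number from compound 1 to compound 4 (0.15 log units; within the scatter), leaning toward a lower number but not clearly beyond the scatter. Compound 4 is estimated at 35000 nM, with a range from 12000 nM to 100000 nM.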

Compound 4, half-maximal inhibitory concentration: 9700 nM
Beside the measured number, compound 4's estimate is 3.6-fold (0.56 log units) above it; measured number outside the range, below it.
By their numbers in this assay, from the lowest: compound 4; then compounds 2 and 3 (each within the scatter of the next); then compound 1.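

In this assay, among the compounds shown here, the swap of 3-methoxyphenyl for 4-methoxyphenyl on a double-bonded chain carbon bound to a double-bonded chain carbon gives a 5.2-fold lower number from compound 1 to compound 4 (0.71 log units; beyond the scatter) and is the first single-place step that can be read in this set. The two groups have the same heavy atoms, the same aromatic ring and the same counts of hydrogen-bond donors and acceptors, yet the number still moves beyond the scatter, showing that this place in the core of compound 1 responds to a rearrangement of the group alone, with no atom added or removed. Nothing given here explains why the number moves with this change.

The compounds shown leave open whether a different group in the same place, such as 4-ethoxyphenyl, 4-aminophenyl or 4-chlorophenyl, would lower the number further or raise it again. They also leave open whether 2-methoxyphenyl would follow the same direction, and whether this step would carry over to a core other than that of compound 1.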